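The source may hold more compounds than are shown below. What is called first, only, known or untested is meant among the compounds shown, and "the series" means these compounds.

Compound 1 `Cc1cc2c(cc1C)C(Cl)=C(C(=O)N/N=C\c1ccc(F)cc1)CCC2` and compound 2 `O=C(N/N=C/C1=C(Cl)c2ccccc2CCC1)c1ccccc1` are built on the same core and differ in what hangs from it. In a functional assay on HeLa cells (Homo sapiens) for inhibition, read by sulforhodamine B assay, with a stated time of 48 h (on this read-out lower numbers stand for stronger inhibition of growth and higher numbers for weaker inhibition of growth), compound 1 gives 2200 nM. For compound 2 only a limit is known: in this assay compound 2 gives > 100000 nM, which is a limit of the measurement and not a number. This is the limit of > 100000 nM in this assay, at which 1 of the 2 values shown sits, so compound 2 stands at the weak end of what the two results show, with no measured value of its own. Compound 3 `Nc1ccccc1C(=O)N/N=C/C1=C(Cl)c2ccccc2CCC1` differs from compound 2 in one place: amino in place of hydrogen on an aromatic carbon, ortho to a large group. For the measured compounds named here, no measured step connects the two compounds, and the data give no handle on the size or direction of the change; the amino group may leave compound 3 at the limit, or lift it somewhat beyond the scatter. Compound 3 is therefore expected to give about 60000 nM in this assay, with a plausible range from 15000 nM to 200000 nM. The step this estimate means, an at least 1.6-fold lower number from compound 2 to compound 3 (0.22 log units; that floor lies within the scatter), is expected to be a small gain at most, with a real chance that only a limit is reported again.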

Compound 3, concentration for 50% growth inhibition: > 100000 nM
Compound 3 was reported as a limit (the forecaster's own chance of this, stated with the estimate: 55%); middle value at least 1.6-fold (0.22 log units) from the limit.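

In this assay compound 3 gives > 100000 nM as a limit of the measurement and not a number. Compound 2 stands at a limit as well, so no step can be read between compound 2 and compound 3. The compounds shown leave open whether going from phenyl to 2-aminophenyl changes growth inhibition at all.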